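The source may hold more compounds than are shown below. What is called first, only, known or untested is meant among the compounds shown, and "the series" means these compounds.

In an ADME assay on MRC5 cells (Homo sapiens) for cytotoxicity, read by fluorescence and resazurin assay, with a stated time of 3 days (a higher number here means that more compound is needed for the effect, a lower number that less compound is needed), compound 1 `O=C1C=CC(O)(c2cc3ccccc3n2S(=O)(=O)c2ccccc2)C=C1` gives 110 nM, compound 2 `COC(=O)CCc1ccc(S(=O)(=O)n2c(C3(O)C=CC(=O)C=C3)cc3ccccc32)cc1` gives 280 nM and compound 3 `CS(=O)(=O)c1ccc(S(=O)(=O)n2c(C3(O)C=CC(=O)C=C3)cc3ccccc32)cc1` gives 39 nM, the lowest of the three. Compound 4 `O=C1C=CC(O)(c2cc3ccccc3n2S(=O)(=O)c2ccc(CCC(=O)O)cc2)C=C1` has 2-carboxyethyl in place of the methylsulfonyl of compound 3, on an aromatic carbon, para to a large group: 2-carboxyethyl in place of methylsulfonyl on an aromatic carbon. Added to the shared core, methylsulfonyl gave a 2.8-fold lower number from compound 1 to compound 3 (0.45 log units; beyond the scatter), whereas 2-(methoxycarbonyl)ethyl gave a 2.5-fold higher number from compound 1 to compound 2 (0.41 log units; beyond the scatter). Compound 2 carries the methyl ester of the incoming chain. The nearest guide is thus the largest step, a 7.2-fold lower number from compound 2 to compound 3 (0.86 log units; beyond the scatter), read in reverse. A step of similar size towards a higher number is therefore expected, estimated as a 7.7-fold higher number from compound 3 to compound 4 (0.89 log units; beyond the scatter). The expected value for compound 4 is 300 nM, with an estimated range of 100 nM to 1000 nM.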

Compound 4, half-maximal effective concentration: 3300 nM
Compound 4: the middle estimate sits 11-fold (1.04 log units) below what was measured, and the stated range ends below it.
By their numbers in this assay, from the lowest: compound 3; then compound 1; then compound 2; then compound 4.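

In this assay, the free acid at this position, on an aromatic carbon para to a large group, separates clearly from its methyl ester (a 12-fold higher number from compound 2 to compound 4 (1.07 log units; beyond the scatter)). Added to the shared core, 2-carboxyethyl gives a large rise (a 30-fold higher number from compound 1 to compound 4 (1.48 log units; beyond the scatter)), whereas the methyl ester gave only a modest one. Its exchange for methylsulfonyl is the largest step among these compounds (an 85-fold higher number from compound 3 to compound 4 (1.93 log units; beyond the scatter)).

As far as these compounds go, whether an amide, an amine or a longer chain ending in a carboxylic acid would behave in the same way stays open. Nothing available explains the size of these steps.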